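Swapping 3-fluorophenyl for 4-methylbenzyl on an amide-type nitrogen

The source may hold more compounds than are shown below. What is called first, only, known or untested is meant among the compounds shown, and "the series" means these compounds.

Measured in a functional assay on Jurkat cells (Homo sapiens) for inhibition, read by MTT assay, with a stated time of 72 h (a lower number here means a stronger inhibitor, a higher number a weaker inhibitor), so far:
- compound 1 `COc1cc(NC(=O)/C=C/c2cccc(OCc3ccccc3)c2)cc(OC)c1OC` gives 3500 nM
- compound 2 `C=C(Br)C(=O)Nc1cccc(/C=C/C(=O)Nc2cccc3ccccc23)c1` gives 680 nM
- compound 3 `C=C(Br)C(=O)Nc1cccc(/C=C/C(=O)Nc2cccc(F)c2)c1` gives 1000 nM

Compound 3, at 1000 nM, lies within the usual scatter of compound 2, at 680 nM. Compound 1, at 3500 nM, has a higher number than compound 3, and that gap goes beyond the scatter.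

The next compound is compound 4 `C=C(Br)C(=O)Nc1cccc(/C=C/C(=O)NCc2ccc(C)cc2)c1`. It carries 4-methylbenzyl in place of 3-fluorophenyl on an amide-type nitrogen.

For the measured compounds named here, no measured compound has a benzyl group at that nitrogen, so the forecast is uncertain. Two different groups stand there in the measured compounds: compound 2 gives 680 nM and compound 3 gives 1000 nM, which is no difference beyond the scatter. In this assay the expected step of a 1.3-fold higher number from compound 3 to compound 4 (0.11 log units; within the scatter) is therefore small, an estimated drift toward a higher number that may stay within the scatter. The estimate for compound 4 is 1300 nM, with an expected range from 450 nM to 4000 nM.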

Compound 4, half-maximal inhibitory concentration: 740 nM
Estimate against measurement, compound 4: 1.8-fold (0.24 log units) above; low and high end bracket the measured number.
By their numbers in this assay, from the lowest: compounds 2, 4 and 3 (each within the scatter of the next); then compound 1.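

In this assay, for the compounds shown here, this is the first direct comparison of two groups on an amide-type nitrogen in the shared core, and exchanging 3-fluorophenyl for 4-methylbenzyl gives a 1.4-fold lower number from compound 3 to compound 4 (0.13 log units; within the scatter). The position therefore accepts a benzyl group carrying a methyl as readily as a fluorinated phenyl group, with no difference that can be told from the scatter. No measurement here bears on why the two groups give such similar results.

From the compounds shown here alone, because both the ring substituent and the way the ring is attached differ in this one exchange, their separate contributions remain unknown. Also open, going by these compounds, is how the number would respond to a phenethyl group on this nitrogen, or to an amine or a carboxylic acid on the benzyl ring.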